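From methoxycarbonyl to carboxy in compound 3

The source may hold more compounds than are shown below. What is called first, only, known or untested is meant among the compounds shown, and "the series" means these compounds.

Measured in a functional assay on DU-145 cells (Homo sapiens) for cytotoxicity, read by trypan blue exclusion, with a stated time of 96 h (on this read-out lower numbers stand for stronger inhibition and higher numbers for weaker inhibition), so far
Compound 1 `COc1cc(OC)c(/C=C/S(=O)(=O)Nc2ccc(OC)c(O)c2)c(OC)c1` gives 30 nM in this test
Compound 2 `COC(=O)C(Nc1cc(NS(=O)(=O)/C=C/c2c(OC)cc(OC)cc2OC)ccc1OC)c1ccc(Br)cc1` gives 7500 nM in this test

Of the two measured compounds, compound 2 stands at the higher number, and its gap to compound 1 lies well beyond the usual scatter. Compound 3 `COc1cc(OC)c(/C=C/S(=O)(=O)Nc2ccc(OC)c(NC(C(=O)O)c3ccc(Br)cc3)c2)c(OC)c1` departs from compound 2 by a single change hydrogen in place of methyl on an oxygen next to a carbonyl group with hydrogen in place of methyl on an oxygen next to a carbonyl group, so methoxycarbonyl becomes carboxy. For the measured compounds named here, no measured pair isolates this change, which leaves the direction uncertain. A moderate move toward stronger inhibition, beyond the scatter, is nevertheless expected in this assay since compound 1 at 30 nM shows that far lower numbers occur among these compounds. The expected change is an estimated 3.8-fold lower number from compound 2 to compound 3 (0.57 log units; beyond the scatter) in this test. For compound 3 the estimate is 2000 nM with an expected range from 200 nM to 15000 nM in this test.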

Compound 3, half-maximal inhibitory concentration: 250 nM
The estimate for compound 3 lay 8.0-fold (0.90 log units) above the measured number; the range from low to high includes it.
By their numbers in this assay, from the lowest: compound 1; then compound 3; then compound 2.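

In this assay, hydrogen in place of methyl on an oxygen next to a carbonyl group, which turns methoxycarbonyl into carboxy, gives a 30-fold lower number from compound 2 to compound 3 (1.48 log units; beyond the scatter), so this one site on the side chain strongly sets the read-out. The carboxy compound still does not match the simpler hydroxy compound: ((4-bromophenyl)(carboxy)methyl)amino in place of hydroxy on an aromatic carbon gives an 8.3-fold higher number from compound 1 to compound 3 (0.92 log units; beyond the scatter), a smaller gap than the one the methyl ester leaves. Nothing available accounts for the size of either step.

The compounds shown leave open whether a primary amide or an ethyl ester in this place would read like the carboxylic acid or like the methyl ester. They also leave open what the 4-bromophenyl group contributes, as none carries a plain phenyl there.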